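Amide in place of acetate on a macrocyclic enone

A few compounds are considered here, and "the series" means these few. Any claim that something is new, unique, unknown or untested is made for them only; others in the source may bear on it.

Measured compounds, in a functional assay on A549 cells (Homo sapiens) for antiproliferative activity, read by MTT assay, with a stated time of 48 h; on this read-out higher numbers stand for weaker inhibition and lower numbers for stronger inhibition:
Compound 1 `CC(=O)OC/C1=C/C[C@](C)(CCC=C(C)C)/C=C/[C@@H](OC(=O)C=C(C)C)[C@](C)(O)/C=C/C1=O` gives 2950 nM.
Compound 2 `CC(C)=CCC[C@]1(C)/C=C/[C@@H](OC(=O)C=C(C)C)[C@](C)(O)/C=C/C(=O)/C(C[Si](C)(C)C(C)(C)C)=C\C1` gives 4200 nM.
Compound 3 `CC(C)=CCC[C@]1(C)/C=C/[C@@H](OC(=O)C=C(C)C)[C@](C)(O)/C=C/[C@H](O)/C(CO)=C\C1` gives > 40000 nM, which is a limit of the assay and not a number.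

Compound 1 holds the lower of the two numbers recorded in this assay. Its nearest neighbour is compound 2, and the step of a 1.4-fold higher number from compound 1 to compound 2 (0.15 log units; within the scatter) lies within the scatter, so the two cannot be placed in order. Going by the values given here, compound 3 reports only a limit, (the limit of > 40000 nM in this assay, at which 1 of the 3 values shown sits), and it differs from compound 1 in more than one place, so no single step can be drawn from it.

Compound 4 `CC(C)=CCC[C@]1(C)/C=C/[C@@H](OC(=O)C=C(C)C)[C@](C)(O)/C=C/C(=O)/C(C(=O)N2CCCC2)=C\C1` carries the change ((pyrrolidin-1-yl)carbonyl in place of acetoxymethyl on a double-bonded ring carbon). Among the compounds with values here, the only measured step at that same site is a 1.4-fold higher number from compound 1 to compound 2 (0.15 log units; within the scatter), in which a bulkier group in place of the acetoxymethyl left the number within the scatter. With a single step at this site and that step flat, there is no basis for expecting a shift beyond the scatter in this assay in either direction. The expected step is therefore small: a 1.2-fold higher number from compound 1 to compound 4 (0.07 log units; within the scatter). Compound 4 is accordingly estimated at 3500 nM, with a range from 1200 nM to 12000 nM.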

Compound 4, half-maximal inhibitory concentration: 13000 nM
Compound 4: middle estimate off by 3.7-fold (0.57 log units), on the low side; measured number above the stated range.
By their numbers in this assay, from the lowest: compounds 1 and 2 (each within the scatter of the next); then compound 4. At a limit, above all of these: compound 3.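

In this assay, this double-bonded ring carbon turns out not to be indifferent to what it carries: replacing acetoxymethyl with (pyrrolidin-1-yl)carbonyl gives a 4.4-fold higher number from compound 1 to compound 4 (0.64 log units; beyond the scatter), whereas the earlier replacement with the silicon-bearing group stayed within the scatter. The two replacements also part from each other, with a 3.1-fold higher number from compound 2 to compound 4 (0.49 log units; beyond the scatter), so a flat first step at this site did not carry over to the amide, although both new steps are modest and compound 4 still returns a number and not a limit. Nothing measured on these compounds accounts for this shift.

The compounds shown leave open whether the higher number goes with the amide carbonyl itself or with the pyrrolidine ring it carries, a question that a dimethylamide, a piperidine amide or a methyl ester at the same carbon would address. They also leave open how a carboxylic acid, or a hydroxymethyl group on the otherwise unchanged core of compound 1, would compare at this position.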